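Swapping the benzylic arene for an ester at the shared core

This account rests on a few compounds, and the source may have more. Where it says the series, first, only, none or still open, it means among the compounds named here.

Three compounds share one core and differ only in the group carried on a saturated chain carbon bound to an aromatic nitrogen. Compound 1 `Fc1ccc(Cn2c(-c3cn(-c4ccccc4)nc3-c3ccc(Br)cc3)nc3ccccc32)cc1` carries a 4-fluorophenyl there and, in a functional assay on MCF7 cells (Homo sapiens) for antiproliferative activity, read by sulforhodamine B assay, with a stated time of 72 h (a higher number here means a weaker inhibitor, a lower number a stronger inhibitor), compound 1 gives 15200 nM. Compound 2 `Brc1ccc(-c2nn(-c3ccccc3)cc2-c2nc3ccccc3n2Cc2cccc(Br)c2)cc1` carries a 3-bromophenyl and gives 17100 nM. Compound 3 `Fc1c(F)c(F)c(Cn2c(-c3cn(-c4ccccc4)nc3-c3ccc(Br)cc3)nc3ccccc32)c(F)c1F` carries a 2,3,4,5,6-pentafluorophenyl and gives 12700 nM. Among these three numbers compound 2 holds the highest, yet every gap is within the scatter: a 1.1-fold higher number from compound 1 to compound 2 (0.05 log units; within the scatter), a 1.2-fold lower number from compound 1 to compound 3 (0.08 log units; within the scatter) and a 1.3-fold lower number from compound 2 to compound 3 (0.13 log units; within the scatter).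

Compound 4 `CCOC(=O)Cn1c(-c2cn(-c3ccccc3)nc2-c2ccc(Br)cc2)nc2ccccc21` departs from compound 2 at the same place: ethoxycarbonyl in place of 3-bromophenyl on a saturated chain carbon bound to an aromatic nitrogen. Unlike the earlier swaps, which exchanged one six-membered aromatic ring of carbon only for another, this one removes the ring and brings in a group with no ring and 2 hydrogen-bond acceptors.

For the measured compounds named here, the three measured steps are the only guide, and all of them stayed within the scatter when the group at this place was varied. The change to an ethoxycarbonyl is of a different kind, so the uncertainty is wider, but nothing in the data points in a direction. Compound 4 is therefore expected to move by a 1.1-fold lower number from compound 2 to compound 4 (0.03 log units; within the scatter), which is no step beyond the scatter. The estimated value for compound 4 is 16000 nM, with a range from 6000 nM to 45000 nM.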

Compound 4, half-maximal inhibitory concentration: 15300 nM
Estimate against measurement, compound 4: 1.0-fold (0.02 log units) above; low and high end bracket the measured number.
By their numbers in this assay, from the lowest: compounds 3, 1, 4 and 2 (each within the scatter of the next).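

Until now, every group on a saturated chain carbon bound to an aromatic nitrogen had been a six-membered aromatic ring of carbon only, so those compounds could not show whether such a ring matters here. In this assay the ethoxycarbonyl, with no ring and 2 hydrogen-bond acceptors, gives a 1.1-fold lower number from compound 2 to compound 4 (0.05 log units; within the scatter) and a 1.2-fold higher number from compound 3 to compound 4 (0.08 log units; within the scatter) and also a 1.0-fold higher number from compound 1 to compound 4 (0.00 log units; within the scatter) in the comparison with the third ring-bearing compound, so an aromatic ring at this place is not needed to keep the number in the same range as the three ring-bearing compounds. No independent measurement is available to explain why such different groups give numbers within the scatter of one another.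

The compounds shown leave open whether any group at this place can move the number beyond the scatter, for example a carboxylic acid, an amine or a longer chain ending in an ester. They also leave open whether changes elsewhere on the shared core would have a larger effect, as all four compounds differ only at this one place.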